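Capping the hydroxy of compound 3 with acetyl

A few compounds are considered here, and "the series" means these few. Any claim that something is new, unique, unknown or untested is made for them only; others in the source may bear on it.

Measured in an ADME assay on HOS cells (Homo sapiens) for cytotoxicity, read by a luciferase reporter and ATP content; on this read-out lower numbers stand for higher toxicity in this test and higher numbers for lower toxicity in this test:
- compound 1 `O=C(NCc1ccc(F)cc1F)c1c(NC2CCCCCC2)c2cccnc2n(O)c1=O`: 68000 nM
- compound 2 `O=C(NCc1ccc(F)cc1F)c1c(NCCCCc2ccccc2)c2cccnc2n(O)c1=O`: 102000 nM
- compound 3 `O=C(NCc1ccc(F)cc1F)c1c(NCCO)c2cccnc2n(O)c1=O`: 24000 nM

Compound 3, at 24000 nM, has the lowest number of the three, and its gaps to the other two lie beyond the scatter. Compound 4 `CC(=O)OCCNc1c(C(=O)NCc2ccc(F)cc2F)c(=O)n(O)c2ncccc12` has not been measured yet. It differs from compound 3 by acetyl in place of hydrogen on an oxygen on a saturated carbon, which turns 2-hydroxyethyl into 2-acetoxyethyl.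

For the measured compounds named here, no measured step changes this hydroxy directly, so the evidence is indirect. The closest steps are a 2.8-fold lower number from compound 1 to compound 3 (0.45 log units; beyond the scatter) and a 4.3-fold lower number from compound 2 to compound 3 (0.63 log units; beyond the scatter). Both end at the 2-hydroxyethyl chain and both are modest. The step of a 1.5-fold higher number from compound 1 to compound 2 (0.18 log units; within the scatter) shows that two quite different groups can sit close together on this read-out. With the free hydroxy gone, part of the drop seen in those two steps is expected to return, so a small rise in this assay is the working expectation, and it may not clear the scatter. The expected step is a 1.5-fold higher number from compound 3 to compound 4 (0.18 log units; within the scatter). For compound 4 the estimate is 36000 nM, with an expected range of 16000 nM to 90000 nM.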

Compound 4, half-maximal cytotoxic concentration: > 250000 nM
Compound 4: a limit, no number; the forecaster's own chance of this, stated with the estimate: 10%; middle value at least 6.9-fold (0.84 log units) from the limit.
By their numbers in this assay, from the lowest: compound 3; then compounds 1 and 2 (each within the scatter of the next). At a limit, above all of these: compound 4.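

In this assay, for the compounds shown here, acetyl in place of hydrogen on this oxygen gives the first large step: an at least 10-fold higher number from compound 3 to compound 4 (1.01 log units; beyond the scatter). The 2-acetoxyethyl chain also separates from both earlier groups, with an at least 2.4-fold higher number from compound 2 to compound 4 (0.38 log units; beyond the scatter) and an at least 3.6-fold higher number from compound 1 to compound 4 (0.56 log units; beyond the scatter), so the low number of compound 3 goes with the free hydroxy and not with the short chain alone, while cycloheptyl and 4-phenylbutyl do not mark the top of the range at this place. Compound 4 stands as a limit and not as a number: the limit of > 250000 nM in this assay, at which 1 of the 4 values shown sits.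

Going by these compounds, how far compound 4 lies past that limit remains open, and so does the full size of all three steps. Also open, on these data alone, is whether a methyl ether, an amine or a carboxylic acid in place of the hydroxy would follow compound 3 or compound 4.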